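The source may report more compounds than this note shows. Statements on the series, on what has been measured and on what is new or still open speak of the compounds shown alone.

Measured in an ADME assay on Vero cells (Chlorocebus sabaeus) for cytotoxicity, read by MTT assay, with a stated time of 72 h; a higher number here means a weaker inhibitor, a lower number a stronger inhibitor:
- compound 1 `CCC[S+]([O-])CCCCN=C=S`: 5640 nM
- compound 2 `[O-][S+](CCCCN=C=S)Cc1ccccc1`: 4850 nM
- compound 3 `[O-][S+](CCCN=C=S)Cc1ccccc1`: 10100 nM

Compound 3, at 10100 nM, lies within the usual scatter of compound 1 and beyond the scatter from compound 2. Compound 4 `[O-][S+](CCCCCN=C=S)Cc1ccccc1` has not yet been measured in this assay. The change to it is a group of 5 heavy atoms (3 carbon, 1 nitrogen, 1 sulfur; no ring) in place of a group of 3 heavy atoms (1 carbon, 1 nitrogen, 1 sulfur; no ring), on a saturated chain carbon, three bonds along the chain from a sulfur. This sits on a saturated chain carbon, three bonds along the chain from a sulfur.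

Among the measured compounds shown here, only one measured step bears on this change, a 2.1-fold higher number from compound 2 to compound 3 (0.32 log units; beyond the scatter). It is modest, and it replaces a larger group with a smaller one at the same place. For the measured compounds named here, the step to compound 4 runs the other way, to a group larger than the one in compound 2, so a lower number is expected. With a single step as precedent, neither its size nor its continuation along the chain is established. The expected change is a 2.2-fold lower number from compound 3 to compound 4 (0.34 log units; beyond the scatter), of similar modest size. For compound 4 the estimated value is 4600 nM, with an expected range of 2000 nM to 10000 nM.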

Compound 4, half-maximal inhibitory concentration: 5850 nM
Compound 4: middle estimate off by 1.3-fold (0.10 log units), on the low side, within the range that was stated.
By their numbers in this assay, from the lowest: compounds 2, 1, 4 and 3 (each within the scatter of the next, the first and the last beyond it).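

In this assay the group of 5 heavy atoms does not separate from the group of 4 heavy atoms, with a 1.2-fold higher number from compound 2 to compound 4 (0.08 log units; within the scatter) as the step between them. Against the group of 3 heavy atoms it also stays inside the scatter, with a 1.7-fold lower number from compound 3 to compound 4 (0.24 log units; within the scatter) as the step, which leaves a 2.1-fold higher number from compound 2 to compound 3 (0.32 log units; beyond the scatter) as the only chain change beyond the scatter and gives no steady trend with chain length across compound 3, compound 2 and compound 4. Nothing measured here accounts for these numbers.

On these data alone, whether a longer chain than that of compound 4 would stay level with compound 2 remains open. Also open, as far as these compounds go, is what an amine or a carboxylic acid would give in place of the group changed here.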